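The source may report more compounds than this note shows. Statements on the series, on what has been measured and on what is new or still open speak of the compounds shown alone.

Measured compounds:
compound 1 `O=C(O)c1ccc(-c2cnc(C(=O)CCCCCCc3ccccc3)o2)cc1` — 60 nM
compound 2 `COc1ccc(-c2cnc(C(=O)CCCCCCc3ccccc3)o2)cc1` — 100 nM

In an assay (Rattus norvegicus) for inhibition of Fatty-acid amide hydrolase 1 (Homo sapiens) (a lower number here means a stronger inhibitor, a higher number a weaker inhibitor), compound 1 gives 60 nM, and compound 2 gives 100 nM. Within the data shown here, compound 2 thus holds the highest of the two numbers, but its only neighbour is compound 1, and the step of a 1.7-fold higher number from compound 1 to compound 2 (0.22 log units; within the scatter) stays within the scatter, so the two compounds cannot be ordered.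

Compound 3 `O=C(CCCCCCc1ccccc1)c1ncc(-c2ccc(O)cc2)o1` has not yet been tested in this assay. It arises from compound 2 by hydrogen in place of methyl on an oxygen on an aromatic ring, so that the 4-methoxyphenyl group becomes a 4-hydroxyphenyl group. Among the measured compounds shown here, the only measured step that bears on this change is the exchange of carboxy for methoxy at the same aromatic carbon; because a 1.7-fold higher number from compound 1 to compound 2 (0.22 log units; within the scatter) lay within the scatter, a polar and a nonpolar substituent on that ring gave much the same number. A step of no more than the scatter is therefore expected for compound 3, with a 1.3-fold lower number from compound 2 to compound 3 (0.10 log units; within the scatter) the estimated change, and compound 3 is expected to give 80 nM, within 30 nM to 250 nM.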

Compound 3, inhibition constant: 140 nM
Beside the measured number, compound 3's estimate is 1.8-fold (0.24 log units) below it; the range from low to high includes it.
By their numbers in this assay, from the lowest: compounds 1, 2 and 3 (each within the scatter of the next, the first and the last beyond it).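

In this assay, hydrogen in place of methyl on the oxygen gives a step within the scatter (a 1.4-fold higher number from compound 2 to compound 3 (0.15 log units; within the scatter)), so methoxy and hydroxy on this aromatic carbon cannot be ordered. Among these compounds, the exchange of carboxy for hydroxy at the same carbon gives the first step beyond the scatter, though a modest one (a 2.3-fold higher number from compound 1 to compound 3 (0.37 log units; beyond the scatter)), which shows that the group at this place can shift the number; compound 2 lies within the scatter of both of the others, so it does not separate them further. No measurement given here accounts for this difference. The compounds shown leave open how an amine or a nitrile on this aromatic carbon would compare with carboxy and hydroxy. They also leave open whether the step from carboxy to hydroxy would persist with a shorter or longer chain in the ketone side arm.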